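Moving a bromine around the benzyl ring of a triazole chalcone

The source may hold more compounds than are shown below. What is called first, only, known or untested is meant among the compounds shown, and "the series" means these compounds.

Measured so far:
- compound 1 `COc1ccc(C(=O)/C=C/c2ccc(OCc3cn(Cc4ccccc4)nn3)cc2)cc1` gives 70%
- compound 2 `COc1ccc(C(=O)/C=C/c2ccc(OCc3cn(Cc4cccc(Br)c4)nn3)cc2)cc1` gives 45%

Both numbers come from a functional assay on MCF7 cells (Homo sapiens) for inhibition, read by MTT assay, with a stated time of 48 h, tested at 10 uM; a higher number here means more inhibition of growth at the concentration tested, a lower number less inhibition of growth. Compound 2 stands at the lower of the two measured values; its nearest neighbour is compound 1, and the step of a number 25 percentage points lower from compound 1 to compound 2 (beyond the scatter) is beyond the scatter, so compound 2 is clearly the weaker of the pair at this concentration.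

Compound 3 `COc1ccc(C(=O)/C=C/c2ccc(OCc3cn(Cc4ccc(Br)cc4)nn3)cc2)cc1` has not been measured. It differs from compound 2 by 4-bromophenyl in place of 3-bromophenyl on a saturated chain carbon bound to an aromatic nitrogen, so the same atoms are present and only the placement of the bromine on the benzyl ring is changed.

Among the measured compounds shown here, only one measured step exists, a number 25 percentage points lower from compound 1 to compound 2 (beyond the scatter), and it concerns adding a bromine, not moving it. It shows that the bromine-bearing compound sits below the unsubstituted one, but says nothing about one bromine position against another. For the measured compounds named here, with no step bearing directly on the change from compound 2 to compound 3, the expectation is a step of a number 2 percentage points higher from compound 2 to compound 3 (within the scatter), no larger than the scatter, in either direction. Compound 3 is therefore estimated at 47%, with a likely range from 30% to 63%.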

Compound 3, percent growth inhibition at one concentration: 53%
For compound 3 the middle estimate is 6 percentage points below the measured one, and the stated range covers the measured number.
By their numbers in this assay, from the lowest: compounds 2 and 3 (each within the scatter of the next); then compound 1.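

In this assay, the change from 3-bromobenzyl to 4-bromobenzyl amounts to a number 8 percentage points higher from compound 2 to compound 3 (within the scatter), so these two placements of the bromine cannot be told apart in this test. The drop seen when a bromine is added now appears at a second placement, a number 17 percentage points lower from compound 1 to compound 3 (beyond the scatter), which leaves compound 1, with no bromine on the benzyl ring, as the most active of the three at this concentration. Nothing available here accounts for the lower numbers of the two bromine compounds or tells whether their placement matters in any other setting.

The compounds shown leave open whether the drop belongs to bromine in particular or would follow any group on this ring, a question that a chlorine or a methyl group on the benzyl ring could help to answer. They also leave open whether a different kind of group, such as an amine or a carboxylic acid on that ring, could give a number as good as or better than that of compound 1, which stands at 70%.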